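Adding a Ring Hydroxy Group to Two Nucleoside Cores

The source may hold more compounds than are shown below. What is called first, only, known or untested is meant among the compounds shown, and "the series" means these compounds.

All three measured compounds were tested in a functional assay on L1210 cells (Mus musculus) for antiproliferative activity; on this read-out higher numbers stand for weaker inhibition and lower numbers for stronger inhibition:

Compound 1 `Cc1nsc2c1ncn2[C@H]1C[C@H](O)[C@@H](CO)O1`: > 100000 nM, a limit of the assay.
Compound 2 `CSc1nc2sncc2n1[C@H]1C[C@H](O)[C@@H](CO)O1`: 20000 nM.
Compound 3 `Cc1nsc2c1ncn2[C@@H]1O[C@H](CO)[C@@H](O)[C@@H]1O`: > 100000 nM, a limit of the assay.

Compound 2 is the only one of the three that gives a number in this assay; the other two sit at a limit. Compound 1 and compound 2 carry different cores, and the difference between the two cores is not broken down here.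

Compound 3 is made from compound 1 by one change, (hydroxy in place of hydrogen on a saturated ring carbon). Because both compounds sit at the limit of > 100000 nM in this assay, at which 2 of the 3 values shown sit, the step that the two limits leave unreadable from compound 1 to compound 3 cannot be read.

Compound 4 `CSc1nc2sncc2n1[C@@H]1O[C@H](CO)[C@@H](O)[C@@H]1O` has not yet been measured. It is made from compound 2 by the same kind of change, (hydroxy in place of hydrogen on a saturated ring carbon); the surroundings differ only in that the place is next to the ring atom that bears a large group rather than next to the ring atom that bears a group of 9 heavy atoms. Since the measured step gives no size, the expectation for compound 4 rests only on the starting point of compound 2 at 20000 nM, and a step of a 2.0-fold higher number from compound 2 to compound 4 (0.30 log units; within the scatter) is estimated with wide uncertainty. Compound 4 is therefore expected to give about 40000 nM, within roughly 8000 nM to 200000 nM, in this assay.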

Compound 4, half-maximal inhibitory concentration: 11000 nM
For compound 4 the middle estimate is 3.6-fold (0.56 log units) above the measured one, and the stated range covers the measured number.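

On the core of compound 2, putting hydroxy in place of hydrogen on a saturated ring carbon gives a 1.8-fold lower number from compound 2 to compound 4 (0.26 log units; within the scatter) in this assay, so the two compounds cannot be told apart on this read-out, and this one pair offers no sign that the extra hydroxy group matters here. Among these compounds, on the core of compound 1, the same change cannot be read because compound 1 and compound 3 both stay at a limit, which is not a number: the limit of > 100000 nM in this assay, at which 2 of the 4 values shown sit. The series therefore holds only one readable step, and with no second size to set beside it, the result does not show whether the change carries from one core to the other, in either agreement or disagreement.

The compounds shown leave open whether a different group on the same saturated ring carbon, such as an amine or a methoxy group, would give a number that stands clear of compound 2. They also leave open how the core of compound 1 would respond to any change that brings its values away from the limit and into a range where a step can be sized.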